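The source may report more compounds than this note shows. Statements on the series, on what has been measured and on what is new or still open speak of the compounds shown alone.

Measured so far:
compound 1 `CCOC(=O)[C@@H]1CCCN(S(=O)(=O)c2ccc(S(=N)(=O)N(CC)CC)cc2)C1` — 2600 nM
compound 2 `CCOC(=O)[C@@H]1CCN(S(=O)(=O)c2ccc(S(=O)(=O)N(CC)CC)cc2)C1` — 8600 nM

In a functional assay on MIA PaCa-2 cells (Homo sapiens) for inhibition, read by MTT assay, with a stated time of 7 days (on this read-out higher numbers stand for weaker inhibition and lower numbers for stronger inhibition), compound 1 gives 2600 nM. That is the lower of the two numbers in hand: compound 2 gives 8600 nM in this assay, a higher number by a gap beyond the scatter. Among the compounds with values here, the two compounds differ in more than one place, so their values show only that compound 1 inhibits more strongly; no single cause can be read from them.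

Compound 3 `CCOC(=O)[C@@H]1CCCN(S(=O)(=O)c2ccc(C(=O)N(CC)CC)cc2)C1` has not yet been measured. It differs from compound 1 by a group of 7 heavy atoms (5 carbon, 1 nitrogen, 1 oxygen; no ring) in place of a group of 8 heavy atoms (4 carbon, 2 nitrogen, 1 oxygen, 1 sulfur; no ring), on an aromatic carbon. Within the data shown here, no pair in hand shows this exchange, so its effect in this assay is unknown. A modest step toward a higher number, or none beyond the scatter, is expected from compound 1 to compound 3, as a 1.5-fold higher number from compound 1 to compound 3 (0.19 log units; within the scatter). For compound 3 the estimate in this assay is 4000 nM, between 1500 nM and 12000 nM.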

Compound 3, half-maximal inhibitory concentration: 800 nM
The estimate for compound 3 lay 5.0-fold (0.70 log units) above the measured number; the measured number lies below the stated range.
By their numbers in this assay, from the lowest: compound 3; then compound 1; then compound 2.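

In this assay, within the data shown here, the exchange of the group of 8 heavy atoms for diethylcarbamoyl gives a 3.3-fold lower number from compound 1 to compound 3 (0.51 log units; beyond the scatter) and so offers the first comparison in which only one place changes. It shows that this place, on an aromatic carbon para to a large group, can by itself move the number beyond the scatter, and that diethylcarbamoyl is accepted there with stronger inhibition. Nothing in hand accounts for the step.

On these data alone, whether the two ethyl groups on the amide nitrogen take part in this gain remains open, as dimethylcarbamoyl, a pyrrolidine amide, a carboxylic acid or a nitrile at this place would show. Also open, as far as these compounds go, is whether diethylcarbamoyl gives a similar step on the core of compound 2.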